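A few compounds are considered here, and "the series" means these few. Any claim that something is new, unique, unknown or untested is made for them only; others in the source may bear on it.

In a functional assay on HepG2 cells (Homo sapiens) for antiproliferative activity, read by MTT assay, with a stated time of 48 h (a higher number here means a weaker inhibitor, a lower number a stronger inhibitor), compound 1 `S=c1oc(-c2ccc3c(c2)OCCO3)nn1CN1CCN(C(c2ccccc2)c2ccccc2)CC1` gives 9120 nM. Compound 2 `Fc1ccccc1N1CCN(Cn2nc(-c3ccc4c(c3)OCCO4)oc2=S)CC1` reaches only the limit of the assay, > 50000 nM. Compound 3 `S=c1oc(-c2ccc3c(c2)OCCO3)nn1CN1CCN(c2cccc(Cl)c2Cl)CC1` also stops at the limit, > 50000 nM. The step that the two limits leave unreadable from compound 2 to compound 3 therefore cannot be sized: both of its values are limits, and compound 3 stands at the limit of > 50000 nM in this assay, at which 2 of the 3 values shown sit. Compound 4 `S=c1oc(-c2ccc3c(c2)OCCO3)nn1CN1CCN(c2cccc(Cl)c2)CC1` differs from compound 3 by hydrogen in place of chloro on an aromatic carbon. Among the compounds with values here, no measured step bears directly on this change; the one readable comparison is that compound 1, carrying a different group on the amine nitrogen in the ring, gave a number while compound 3 did not. Compound 4 is therefore expected to stay weak, with an estimated step of an at least 1.1-fold lower number from compound 3 to compound 4 (0.04 log units; that floor lies within the scatter) and an estimated value of 45000 nM, between 12000 nM and 100000 nM.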

Compound 4, half-maximal inhibitory concentration: > 50000 nM
Compound 4: no number, only a limit; the forecaster's own chance of this, stated with the estimate: 55%; at least 1.1-fold (0.04 log units) between middle value and limit.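

Compound 4 also gives only a limit (> 50000 nM), so no new step can be read from compound 2 or compound 3 to compound 4. On these data alone, whether hydrogen in place of chloro changes the activity at all in this assay stays open.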